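The source may hold more compounds than are shown below. What is called first, only, known or untested is meant among the compounds shown, and "the series" means these compounds.

Measured so far in a functional assay on A549 cells (Homo sapiens) for antiproliferative activity, read by MTT assay; on this read-out higher numbers stand for weaker inhibition and lower numbers for stronger inhibition:
compound 1, `Cn1c(=O)c(=O)n(C2CCCC2)c2nc(N/N=C/c3ccccc3)ncc21`
compound 2, `Cn1c(=O)c(=O)n(C2CCCC2)c2nc(N/N=C/c3cc(C(F)(F)F)c(O)c(C(F)(F)F)c3)ncc21`
compound 3, `Cc1cc(C)c(/C=N/Nc2ncc3c(n2)n(C2CCCC2)c(=O)c(=O)n3C)c(C)c1`

Compound 1 reaches only the limit of this assay, > 100000 nM. Compound 2 gives 22900 nM. Compound 3 gives 12000 nM.

Where compound 3 stands: its number and that of compound 2 sit within the scatter of each other, so the two cannot be ordered; the value of compound 1 is a limit and not a number. Going by the values given here, the one measured change at the carbon with a double bond to nitrogen is an at least 8.3-fold lower number from compound 1 to compound 3 (0.92 log units; beyond the scatter), and its size is bounded on one side by the limit of > 100000 nM in this assay, at which 1 of the 3 values shown sits.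

Compound 4, `Cn1c(=O)c(=O)n(C2CCCC2)c2nc(N/N=C/c3ccc(F)cc3F)ncc21`, differs from compound 3 in one place: 2,4-difluorophenyl in place of 2,4,6-trimethylphenyl on a carbon with a double bond to nitrogen. Among the compounds with values here, the only step bearing on this position is an at least 8.3-fold lower number from compound 1 to compound 3 (0.92 log units; beyond the scatter), which shows that a substituted phenyl on this carbon gives a lower number than phenyl does; compound 2, carrying a different substituted phenyl, sits within the scatter of compound 3. Whether 2,4-difluorophenyl sits nearer to 2,4,6-trimethylphenyl or nearer to phenyl is not shown. The expected step is a 2.1-fold higher number from compound 3 to compound 4 (0.32 log units; beyond the scatter), towards a somewhat higher number. Compound 4 is expected to give about 25000 nM, in the range 8000 nM to 80000 nM.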

Compound 4, half-maximal inhibitory concentration: 18300 nM
Beside the measured number, compound 4's estimate is 1.4-fold (0.14 log units) above it; low and high end bracket the measured number.
By their numbers in this assay, from the lowest: compounds 3, 4 and 2 (each within the scatter of the next). At a limit, above all of these: compound 1.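

In this assay, with 2,4-difluorophenyl in place of 2,4,6-trimethylphenyl on a carbon with a double bond to nitrogen, the step is a 1.5-fold higher number from compound 3 to compound 4 (0.18 log units; within the scatter), so these two groups cannot be ordered. Phenyl on the same carbon is now separated from a second substituted phenyl, one that shares no substituent with 2,4,6-trimethylphenyl, and the step is an at least 5.4-fold lower number from compound 1 to compound 4 (0.73 log units; beyond the scatter). The full size of this step cannot be read, since the value of compound 1 is a limit and not a number: the limit of > 100000 nM in this assay, at which 1 of the 4 values shown sits.

Still open, as far as these compounds go, is whether a group of another kind on the phenyl, such as an amine or a carboxylic acid, would give a number beyond the scatter of compound 3 and compound 4. Also open, from the compounds shown here alone, are whether a single fluorine on the phenyl would be enough to separate it from phenyl, and whether an aromatic ring is needed on this carbon at all, which a cyclohexyl group there would test.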